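Adding Fluoro to the Chlorophenyl Ring of Compound 2

The source may hold more compounds than are shown below. What is called first, only, known or untested is meant among the compounds shown, and "the series" means these compounds.

Of the compounds shown here, two sharing one core have been measured. Among the compounds with values here, compound 1 `CCCCCCCCCCCCNc1nc(SCc2ccc(C(F)(F)F)cc2)nc2ccccc12` is the first of them; in a functional assay on MGC-803 cells (Homo sapiens) for cytotoxicity, read by MTT assay, with a stated time of 72 h (a lower number here means a stronger inhibitor, a higher number a weaker inhibitor), compound 1 reaches only > 50000 nM, which is a limit of the assay rather than a measured number. Compound 2 `FC(F)(F)c1ccc(CSc2nc(Nc3cccc(Cl)c3)c3ccccc3n2)cc1` is the second, and in this assay compound 2 gives 14600 nM. Among the numbers shown, this is the only measured value; the other entry sits at a limit (the limit of > 50000 nM in this assay, at which 1 of the 2 values shown sits), so no measured step between compounds is available.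

Compound 3 `Fc1ccc(Nc2nc(SCc3ccc(C(F)(F)F)cc3)nc3ccccc23)cc1Cl` has not yet been tested in this assay. It differs from compound 2 by fluoro in place of hydrogen on an aromatic carbon. Within the data shown here, with no measured step to anchor so small a change, the expected step is estimated to lie within the scatter of repeated measurements, in no clear direction: a 1.3-fold lower number from compound 2 to compound 3 (0.12 log units; within the scatter). Compound 3 is expected to give about 11000 nM, with a likely range from 4000 nM to 30000 nM.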

Compound 3, half-maximal inhibitory concentration: > 50000 nM
Compound 3 gave a limit, no number (the forecaster's own chance of this, stated with the estimate: 10%); middle value at least 4.5-fold (0.65 log units) from the limit.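

In this assay, placing fluoro on the aromatic carbon ortho to the chloro group and para to a large group, which turns 3-chlorophenyl into 3-chloro-4-fluorophenyl, gives an at least 3.4-fold higher number from compound 2 to compound 3 (0.53 log units; beyond the scatter). The value of compound 3, > 50000 nM, is a limit and not a number, so only a minimum size for this step can be read. Even so, the result shows that this ring carbon is sensitive: a change of one hydrogen to one fluorine atom is enough to move the result beyond the scatter.

Within the data shown here, compound 2 remains the only compound here with a measured number, and the other values sit at the assay's limit: the limit of > 50000 nM in this assay, at which 2 of the 3 values shown sit. Whether a methoxy group, an amine or a carboxylic acid on this same carbon would keep a measurable number remains open.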